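The compounds below may be only part of what the source reports. "The series", "measured", "known", "first", "only" and "open" are said of these compounds alone.

Working notes on the series. The shared core carries one variable group on an aromatic carbon: allyloxy in compound 1 `C=CCOc1nc(N)nc2c1ncn2/C=C1/CC1(CO)CO`, isopropylamino in compound 2 `CC(C)Nc1nc(N)nc2c1ncn2/C=C1/CC1(CO)CO` and propylamino in compound 3 `CCCNc1nc(N)nc2c1ncn2/C=C1/CC1(CO)CO`. In an ADME assay on Akata cells (Homo sapiens) for cytotoxicity, with a stated time of 7 days (a lower number here means that less compound is tolerated, a higher number that more compound is tolerated), compound 1 gives > 20000 nM, which is a limit. Compound 2 gives > 24000 nM, also a limit. Compound 3 gives > 24000 nM, again a limit, so the starting point has no number.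

Compound 4 `CCCCCOc1nc(N)nc2c1ncn2/C=C1/CC1(CO)CO` differs from compound 3 by pentyloxy in place of propylamino on an aromatic carbon, with pentyloxy in place of propylamino on an aromatic carbon. The relevant measured changes are a step that the two limits leave unreadable from compound 1 to compound 3 and a step that the two limits leave unreadable from compound 2 to compound 3. Neither gives a size. The closest guide is the other member with an oxygen-linked chain, which is compound 1 at > 20000 nM, a limit. In this assay a small shift toward less compound tolerated is expected, if any, and compound 4 may again return only a limit. The estimated change is an at least 1.3-fold lower number from compound 3 to compound 4 (0.12 log units; that floor lies within the scatter). For compound 4 the estimate is 18000 nM, with an expected range of 6000 nM to 40000 nM.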

Compound 4, half-maximal cytotoxic concentration: > 20000 nM
Compound 4: no number, only a limit; the forecaster's own chance of this, stated with the estimate: 55%; middle value at least 1.1-fold (0.04 log units) away from the limit.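

For the compounds shown here, compound 4 returns only a limit, as do compound 1, compound 2 and compound 3, so no step between compound 4 and any of these three can be read. The compounds shown leave open whether exchanging these groups on the aromatic carbon changes the half-maximal cytotoxic concentration in this assay at all.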